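What a nitro group might do to compound 3

The compounds below may be only part of what the source reports. "The series", "measured", "known", "first", "only" and "open" are said of these compounds alone.

Three compounds share a core and differ in a single group. In a functional assay on HepG2 cells (Homo sapiens) for cytotoxicity, read by MTT assay, with a stated time of 72 h (on this read-out higher numbers stand for weaker inhibition and lower numbers for stronger inhibition), compound 1 `CC[S+]([O-])CCCCN=C=S` gives 5350 nM, compound 2 `[O-][S+](CCCCN=C=S)C1CCCC1` gives 3640 nM, and compound 3 `[O-][S+](CCCCN=C=S)Cc1ccccc1` gives 2850 nM. Compound 3 stands within the usual scatter of both others, so these numbers set no order among the three.

Compound 4 `O=[N+]([O-])c1ccc(C[S+]([O-])CCCCN=C=S)cc1` is compound 3 with nitro in place of hydrogen on an aromatic carbon, para to a large group: nitro in place of hydrogen on an aromatic carbon. Within the data shown here, no two measured compounds differ in just one place, so no measured step shows what a change of this kind does. The expectation therefore rests on compound 3 at 2850 nM and on how closely the three values agree, even with different groups. The estimated change, a 1.1-fold lower number from compound 3 to compound 4 (0.06 log units; within the scatter), is expected to stay within the scatter, with no clear direction. For compound 4, the estimated value in this assay is 2500 nM, with an expected range from 1200 nM to 5200 nM.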

Compound 4, half-maximal inhibitory concentration: 3180 nM
Estimate against measurement, compound 4: 1.3-fold (0.10 log units) below; the range from low to high includes it.
By their numbers in this assay, from the lowest: compounds 3, 4, 2 and 1 (each within the scatter of the next).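

Among these compounds, this is the first measured change in a single place: nitro in place of hydrogen on an aromatic carbon, para to a large group, gives a 1.1-fold higher number from compound 3 to compound 4 (0.05 log units; within the scatter) in this assay. Among the compounds shown here, the earlier compounds differed only in the group on the sulfur and offered no step of this kind, so this is the first sign that this ring position can carry nitro without a change this assay can separate from the scatter. Nothing measured here explains the result.

One step with one group cannot show whether an amine or a carboxylic acid in the same place would also stay within the scatter. The compounds shown also leave open what a longer chain in the shared core would do to the number.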